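The compounds below may be only part of what the source reports. "The series", "measured", "known", "first", "only" and "open" are said of these compounds alone.

Compound 1 `c1ccc(Oc2ccc3c(NCCCNCc4ccco4)ccnc3c2)cc1` is the starting point of this small set; in an ADME assay on HepG2 cells (Homo sapiens) for cytotoxicity, read by luminescence, CellTiter-Glo and ATP content, with a stated time of 72 h (a lower number here means that less compound is needed, a higher number that more compound is needed for the effect), compound 1 gives 15200 nM. Going by the values given here, compound 2 `c1ccc(-c2ccc3c(NCCCNCc4ccco4)ccnc3c2)cc1` gives 5920 nM in this assay, and the only step between measured neighbours that differ in one place is a 2.6-fold lower number from compound 1 to compound 2 (0.41 log units; beyond the scatter). Compound 3 `COc1ccc(F)cc1CNCCCNc1ccnc2cc(CCC(C)C)ccc12` gives 890 nM in this assay, the lowest of the three numbers, separated from compound 2 and still more from compound 1 by gaps beyond the scatter.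

Compound 4 `CC(C)CCc1ccc2c(NCCCNCc3ccco3)ccnc2c1` has not yet been measured. It differs from compound 3 in one place: furan-2-yl in place of 5-fluoro-2-methoxyphenyl on a saturated chain carbon bound to an amine nitrogen. Among the compounds with values here, no measured step bears directly on this change. The step from compound 1 to compound 2 concerns phenyl in place of phenoxy, a different change at a different place, and it says nothing about exchanging the group on the chain carbon bound to the amine nitrogen. What the numbers do show is that compound 1 and compound 2, both carrying (furan-2-yl)methyl, give higher numbers than compound 3, though each of them also differs from compound 3 elsewhere. A modest upward step in this assay is therefore expected, with wide uncertainty; the step estimated is a 2.8-fold higher number from compound 3 to compound 4 (0.45 log units; beyond the scatter). Compound 4 is expected to give 2500 nM, within a range from 900 nM to 7000 nM.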

Compound 4, half-maximal effective concentration: 11200 nM
For compound 4 the middle estimate is 4.5-fold (0.65 log units) below the measured one, outside the stated range (above it).
By their numbers in this assay, from the lowest: compound 3; then compounds 2, 4 and 1 (each within the scatter of the next, the first and the last beyond it).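

In this assay the step from furan-2-yl in place of 5-fluoro-2-methoxyphenyl on a saturated chain carbon bound to an amine nitrogen is the only one in this set that changes that place alone, and with isopentyl held on the aromatic carbon it is large: a 13-fold higher number from compound 3 to compound 4 (1.10 log units; beyond the scatter) in this pair, so the low number of compound 3 goes with 5-fluoro-2-methoxyphenyl and not with isopentyl. With (furan-2-yl)methyl held constant, isopentyl in place of phenyl gives a 1.9-fold higher number from compound 2 to compound 4 (0.28 log units; within the scatter) and isopentyl in place of phenoxy gives a 1.4-fold lower number from compound 1 to compound 4 (0.13 log units; within the scatter) and so, although compound 1 and compound 2 stand beyond the scatter of each other, isopentyl is not told apart from either group. Nothing given here explains why exchanging the group at the chain carbon has so large an effect.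

The compounds shown leave open whether the step follows the fluorine, the methoxy group or the six-membered ring itself, which a plain benzyl or a 2-methoxybenzyl group would separate. They also leave open whether 5-fluoro-2-methoxybenzyl gives a step of similar size with phenyl or phenoxy on the aromatic carbon.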